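The source may report more compounds than this note shows. Statements on the series, on what has been measured and on what is new or still open speak of the compounds shown alone.

Compound 1 `COc1cc(N(Cc2nc3ccccc3[nH]2)C(=O)c2ccccc2)cc(OC)c1OC`: in a functional assay on PC-3 cells (Homo sapiens) for inhibition, read by MTT assay, with a stated time of 48 h (on this read-out higher numbers stand for weaker inhibition and lower numbers for stronger inhibition), compound 1 gives > 50000 nM, which is a limit of the assay and not a number.
Compound 2 `COc1cc(N(Cc2nc3ccccc3[nH]2)C(=O)c2ccc(F)cc2)cc(OC)c1OC`: compound 2 gives 21900 nM.
Compound 3 `COc1cc(N(Cc2nc3ccccc3[nH]2)C(=O)c2ccc(C(C)(C)C)cc2)cc(OC)c1OC`: compound 3 gives 46000 nM.

Of the two numbers measured, compound 3 shows the highest one; the nearest is compound 2, and the step is a 2.1-fold higher number from compound 2 to compound 3 (0.32 log units; beyond the scatter). Compound 1 sits at the limit of > 50000 nM in this assay, at which 1 of the 3 values shown sits.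

Compound 4 `COc1ccc(C(=O)N(Cc2nc3ccccc3[nH]2)c2cc(OC)c(OC)c(OC)c2)cc1OC` has not yet been tested. It differs from compound 3 in one place: 3,4-dimethoxyphenyl in place of 4-(tert-butyl)phenyl on a carbonyl carbon. All three measured steps change a group on the ring that sits on that carbonyl carbon. Fluoro for hydrogen gave an at least 2.2-fold lower number from compound 1 to compound 2 (0.35 log units; beyond the scatter), tert-butyl for hydrogen gave an at least 1.0-fold lower number from compound 1 to compound 3 (0.03 log units; that floor lies within the scatter), and tert-butyl for fluoro gave a 2.1-fold higher number from compound 2 to compound 3 (0.32 log units; beyond the scatter). Among the compounds with values here, none of them involves a methoxy group, so the direction for compound 4 rests on no direct precedent; the sizes seen, however, are modest, and a step of similar size or none beyond the scatter is expected.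

Compound 4 is therefore expected to give about 30000 nM in this assay, with a likely range from 12000 nM to 50000 nM. The expected step from compound 3 is a 1.5-fold lower number from compound 3 to compound 4 (0.19 log units; within the scatter).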

Compound 4, half-maximal inhibitory concentration: 34900 nM
Compound 4: the middle estimate sits 1.2-fold (0.07 log units) below what was measured, within the range that was stated.
By their numbers in this assay, from the lowest: compounds 2, 4 and 3 (each within the scatter of the next, the first and the last beyond it). At a limit, above all of these: compound 1.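

In this assay, the 3,4-dimethoxyphenyl group of compound 4 brings oxygen atoms and two hydrogen-bond acceptors to this carbonyl carbon, yet it cannot be told apart from either substituted ring measured earlier: a 1.3-fold lower number from compound 3 to compound 4 (0.12 log units; within the scatter) and a 1.6-fold higher number from compound 2 to compound 4 (0.20 log units; within the scatter). Compound 2 and compound 3 do differ beyond the scatter, so compound 4 does not add a clear third level; its number simply cannot be separated from either of theirs, and these data give no sign that adding hydrogen-bond acceptors here changes the read-out. Against the unsubstituted phenyl ring, the comparison gives only a floor that does not clear the scatter, an at least 1.4-fold lower number from compound 1 to compound 4 (0.15 log units; that floor lies within the scatter), and compound 1 itself carries a limit of the assay and not a number: the limit of > 50000 nM in this assay, at which 1 of the 4 values shown sits.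

Open, going by these compounds, is whether a single methoxy group on this ring would read the same as the pair, and whether an amine or a carboxylic acid in that place would move the number beyond the scatter. All the steps shown change only this ring, so the effect of any change elsewhere on the shared core also stays open.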